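Replacing 4-methylphenyl with 2-chlorophenyl in the series

The compounds below may be only part of what the source reports. "The series", "measured", "known", "first", "only" and "open" are said of these compounds alone.

Values in a functional assay on HCT-116 cells (Homo sapiens) for cytotoxicity, read by MTT assay, with a stated time of 48 h (on this read-out lower numbers stand for stronger inhibition and higher numbers for weaker inhibition), stand as follows
compound 1 `COc1cc(/C=C/C(=O)C2=C(/C=C/c3ccc(O)c(OC)c3)NC(=O)NC2c2ccccc2)ccc1O` gives 25000 nM
compound 2 `COc1cc(/C=C/C(=O)C2=C(/C=C/c3ccc(O)c(OC)c3)NC(=O)NC2c2ccc(C)cc2)ccc1O` gives 12500 nM
compound 3 `COc1cc(/C=C/C(=O)C2=C(/C=C/c3ccc(O)c(OC)c3)NC(=O)NC2c2ccccc2O)ccc1O` gives 100000 nM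

Compound 2 cannot be separated from compound 1 (a 2.0-fold lower number from compound 1 to compound 2 (0.30 log units; within the scatter)) and lies clearly under compound 3 (an 8.0-fold higher number from compound 2 to compound 3 (0.90 log units; beyond the scatter)). Compound 4 `COc1cc(/C=C/C(=O)C2=C(/C=C/c3ccc(O)c(OC)c3)NC(=O)NC2c2ccccc2Cl)ccc1O` carries 2-chlorophenyl in place of 4-methylphenyl on a saturated ring carbon. Going by the values given here, the closest precedent is compound 3, whose 2-hydroxyphenyl replaces the same group, and its hydroxy step from the parent is also a rise (a 4.0-fold higher number from compound 1 to compound 3 (0.60 log units; beyond the scatter)). Among the compounds with values here, the series holds no chlorine compound, so only part of that rise is expected to carry over. The estimated step (a 1.6-fold higher number from compound 2 to compound 4 (0.20 log units; within the scatter)) points to a higher number and is not expected to lie clearly beyond the scatter. For compound 4 the expected value is 20000 nM (estimated range 8000 nM to 60000 nM).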

Compound 4, half-maximal inhibitory concentration: 50000 nM
Estimate against measurement, compound 4: 2.5-fold (0.40 log units) below; low and high end bracket the measured number.
By their numbers in this assay, from the lowest: compounds 2, 1, 4 and 3 (each within the scatter of the next, the first and the last beyond it).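

In this assay, 2-chlorophenyl in place of 4-methylphenyl gives a step beyond the scatter (a 4.0-fold higher number from compound 2 to compound 4 (0.60 log units; beyond the scatter)), so this saturated ring carbon responds to a chloro substituent as well as to a hydroxy one. Chloro on the phenyl ring still cannot be separated from hydrogen (a 2.0-fold higher number from compound 1 to compound 4 (0.30 log units; within the scatter)) or from hydroxy (a 2.0-fold lower number from compound 3 to compound 4 (0.30 log units; within the scatter)). No measured evidence bears on this result. Open, on these data alone, are how an amine or a carboxylic acid on this aromatic ring would read, and whether the step from compound 2 follows from gaining chloro or from losing methyl.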